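Compound 3 to compound 4: a shorter sulfur chain

A few compounds are considered here, and "the series" means these few. Any claim that something is new, unique, unknown or untested is made for them only; others in the source may bear on it.

Measured in an ADME assay on MOLT-3 cells (Homo sapiens) for cytotoxicity, with a stated time of 7 days; on this read-out higher numbers stand for lower toxicity in this test and lower numbers for higher toxicity in this test:
compound 1 `C=CCOc1nc(N)nc2c1ncn2/C=C1/CC1(CO)CO`: > 20000 nM (a limit)
compound 2 `Nc1nc(NCc2ccccc2)c2ncn(/C=C3/CC3(CO)CO)c2n1`: > 20000 nM (a limit)
compound 3 `CCCCCCCCSc1nc(N)nc2c1ncn2/C=C1/CC1(CO)CO`: > 20000 nM (a limit)

Compound 3 gives > 20000 nM, which is a limit and not a number. The same holds across the series, which shows (the limit of > 20000 nM in this assay, at which 3 of the 3 values shown sit). None of the three compounds goes against this.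

Compound 4 `CSc1nc(N)nc2c1ncn2/C=C1/CC1(CO)CO` has not yet been measured. It carries methylsulfanyl where compound 3 carries octylsulfanyl, with hydrogen in place of heptyl on a saturated chain carbon bound to a sulfur.

For the measured compounds named here, no measured step covers this chain change directly. The nearest are those that change the group on the aromatic carbon: a step that the two limits leave unreadable from compound 1 to compound 3 and a step that the two limits leave unreadable from compound 2 to compound 3. The remaining one is a step that the two limits leave unreadable from compound 1 to compound 2. As far as these compounds go, none of these has a readable size, so the direction of any change in this assay stays open.

Allyloxy, benzylamino and octylsulfanyl all leave the read-out at the limit, so compound 4 is expected to stay there too, with no step beyond the scatter. The expected change is a step that the limit leaves unreadable from compound 3 to compound 4. For compound 4 the estimate is 30000 nM, with an expected range from 12000 nM to 60000 nM.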

Compound 4, half-maximal cytotoxic concentration: > 20000 nM
Compound 4 ended at the assay's limit (the forecaster's own chance of this, stated with the estimate: 85%); the middle value does not contradict the limit.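

In this assay compound 4 gives > 20000 nM, which is a limit and not a number. No new step can be read from compound 1, compound 2 or compound 3 to compound 4. The compounds shown leave open how these groups on the aromatic carbon, including the two sulfur chains, compare on this read-out, with every value at one limit: the limit of > 20000 nM in this assay, at which 4 of the 4 values shown sit.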